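Swapping the Hydroxy Ring for a Dichloro Ring

This account rests on a few compounds, and the source may have more. Where it says the series, first, only, none or still open, it means among the compounds named here.

In a functional assay on A549 cells (Homo sapiens) for cytotoxicity, read by MTT assay, with a stated time of 72 h (a higher number here means a weaker inhibitor, a lower number a stronger inhibitor), three compounds built on a shared core have been measured. Compound 1 `COc1ccc(/C=C2\CCC/C(=C\c3cccc(Br)c3)C2=O)cc1OC` gives 12800 nM and compound 2 `COc1ccc(/C=C2\CCC/C(=C\c3ccc(Br)cc3)C2=O)cc1OC` gives 16000 nM. These two bromo compounds differ only in where the bromo group sits, and the step between them, a 1.3-fold higher number from compound 1 to compound 2 (0.10 log units; within the scatter), does not separate them. Compound 3 `COc1ccc(/C=C2\CCC/C(=C\c3cccc(O)c3)C2=O)cc1OC` has the lowest number of the three at 4300 nM, clearly beyond the scatter from both bromo compounds.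

The next compound, compound 4 `COc1ccc(/C=C2\CCC/C(=C\c3ccc(Cl)c(Cl)c3)C2=O)cc1OC`, has 3,4-dichlorophenyl in place of 3-hydroxyphenyl on a double-bonded chain carbon bound to a double-bonded ring carbon. Going by the values given here, two measured steps bear on this change, a 3.0-fold lower number from compound 1 to compound 3 (0.47 log units; beyond the scatter) and a 3.7-fold lower number from compound 2 to compound 3 (0.57 log units; beyond the scatter). Both are modest, and both end at the hydroxy compound, whereas the new change leaves it for a ring without the hydroxy group. Among the compounds with values here, no chloro compound has been measured, and no compound with two groups on this ring, so the bromo compounds are only an approximate guide. A modest rise of similar size is therefore expected, and the expected step is a 2.6-fold higher number from compound 3 to compound 4 (0.41 log units; beyond the scatter). For compound 4 the estimate is 11000 nM, with an expected range of 4500 nM to 25000 nM.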

Compound 4, half-maximal inhibitory concentration: 6900 nM
Compound 4: the middle estimate sits 1.6-fold (0.20 log units) above what was measured; measured number inside the range.
By their numbers in this assay, from the lowest: compounds 3, 4, 1 and 2 (each within the scatter of the next, the first and the last beyond it).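

Compound 4 shows that this position does not depend on keeping 3-hydroxyphenyl: in this assay the change to 3,4-dichlorophenyl, which has no hydrogen-bond donor, gives a 1.6-fold higher number from compound 3 to compound 4 (0.21 log units; within the scatter) and so does not separate the two compounds. The dichloro ring also stands differently against the two bromo rings, with a 2.3-fold lower number from compound 2 to compound 4 (0.37 log units; beyond the scatter) but only a 1.9-fold lower number from compound 1 to compound 4 (0.27 log units; within the scatter) on the other side, so it separates from compound 2 and not from compound 1. The clear gaps seen earlier between compound 3 and the bromo compounds therefore cannot be read as a simple effect of losing the hydroxy group, and no measurement shown here explains how these rings differ in this assay.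

The compounds shown leave open what each chloro group contributes, since no ring with a single chloro group stands among them to set against compound 4. They also leave open how this position would respond to a quite different group on the ring, such as an amine or a carboxylic acid, as every ring shown carries only hydroxy or halogen.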